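Fluoro for chloro: an expected small drop in lipophilicity

The compounds below may be only part of what the source reports. "The series", "measured", "known", "first", "only" and "open" are said of these compounds alone.

Compound 1 `S=C(N/N=C/c1ccc(Oc2ccc3ccccc3c2)cc1)Nc1ccc(Cl)cc1` is the more lipophilic of the two compounds measured in a physicochemical assay for lipophilicity, in phosphate buffer, measured as octanol-water partition, with a stated time of 24 h; a lower number here means a more polar compound, a higher number a more lipophilic compound: in this assay compound 1 gives 6.96, while compound 2 `O=[N+]([O-])c1ccc(Oc2ccc(/C=N/NC(=S)Nc3ccc(Cl)cc3)cc2)cc1` gives 5.52, a step of a number 1.44 log units lower from compound 1 to compound 2 (beyond the scatter). Compound 3 `Fc1ccc(NC(=S)N/N=C/c2ccc(Oc3ccc4ccccc4c3)cc2)cc1` differs from compound 1 in one place, (fluoro in place of chloro on an aromatic carbon). Within the data shown here, the only measured step concerns a different part of the shared core, so no measured step bears directly on this change. From the structural change alone, a modest decrease in this assay beyond the scatter is expected, a step of a number 0.51 log units lower from compound 1 to compound 3 (beyond the scatter). Compound 3 is therefore estimated at 6.45, in a range from 6.05 to 6.85.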

Compound 3, partition coefficient: 6.2
Compound 3: middle estimate off by 0.25 log units, on the high side, within the range that was stated.
By their numbers in this assay, from the lowest: compound 2; then compound 3; then compound 1.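

Fluoro in place of chloro exchanges one heavy atom for another, with no ring, hydrogen-bond donor, acceptor or net charge entering or leaving, yet this assay records a number 0.76 log units lower from compound 1 to compound 3 (beyond the scatter). This position, on an aromatic carbon para to a large group, therefore registers a change even this small, beyond the scatter. Nothing measured here accounts for the size of the step.

From the compounds shown here alone, how an amine, a methyl or a carboxylic acid would read at this position remains open. Also open, going by these compounds, is whether the same exchange would give a similar step with the 4-nitrophenyl group of compound 2 on the other side.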